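Compound 3 to compound 4: a 3,4-dichlorophenyl swap

A few compounds are considered here, and "the series" means these few. Any claim that something is new, unique, unknown or untested is made for them only; others in the source may bear on it.

Measured so far in an in vitro ADME assay on microsomes from liver (Mus musculus) for pharmacokinetics, read by LC-MS, with a stated time of 10 min, tested at 1 uM; a higher number here means faster removal of the compound, a lower number slower removal:
- compound 1 `Cc1ccc(NC(=O)[C@H]2CN(C)C[C@@H]2c2ccc(/C=C/C(=O)Nc3ccccc3N)cc2)cc1`: 62 mL/min/kg
- compound 2 `Cc1cccc(NC(=O)[C@H]2CN(C)C[C@@H]2c2ccc(/C=C/C(=O)Nc3ccccc3N)cc2)c1`: 74 mL/min/kg
- compound 3 `Cc1cc(NC(=O)[C@H]2CN(C)C[C@@H]2c2ccc(/C=C/C(=O)Nc3ccccc3N)cc2)ccc1F`: 62 mL/min/kg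

Compound 3, at 62 mL/min/kg, stands level with compound 1, and compound 2 lies within the usual scatter of both. The next compound, compound 4 `CN1C[C@H](C(=O)Nc2ccc(Cl)c(Cl)c2)[C@@H](c2ccc(/C=C/C(=O)Nc3ccccc3N)cc2)C1`, keeps the shared core and changes one group: 3,4-dichlorophenyl in place of 4-fluoro-3-methylphenyl on an amide-type nitrogen.

Among the measured compounds shown here, three measured steps bear on this change, since each alters the group at that same place. Putting 3-methylphenyl in place of 4-methylphenyl gives a 1.2-fold higher number from compound 1 to compound 2 (0.08 log units; within the scatter). Putting 4-fluoro-3-methylphenyl in place of 4-methylphenyl gives no change at the digits printed from compound 1 to compound 3 (within the scatter). Putting fluoro in place of hydrogen on an aromatic carbon gives a 1.2-fold lower number from compound 2 to compound 3 (0.08 log units; within the scatter).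

Across these three compounds, no swap has moved the clearance beyond the scatter. For the measured compounds named here, no compound with chlorine has been measured, however, so these steps are only an indirect guide and the range must stay wide. The expected change is a 1.0-fold lower number from compound 3 to compound 4 (0.01 log units; within the scatter), which means no shift beyond the scatter is anticipated in this assay. Compound 4 is estimated at 60 mL/min/kg, with an expected range from 35 mL/min/kg to 100 mL/min/kg.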

Compound 4, clearance: 36 mL/min/kg
Compound 4: middle estimate off by 1.7-fold (0.22 log units), on the high side; the range from low to high includes it.
By their numbers in this assay, from the lowest: compounds 4, 1, 3 and 2 (each within the scatter of the next, the first and the last beyond it).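

At this amide-type nitrogen, 3,4-dichlorophenyl is the first group shown to carry chlorine, and in this assay it gives the first step at this place to pass beyond the scatter, though only modestly: a 2.1-fold lower number from compound 2 to compound 4 (0.31 log units; beyond the scatter). The other two comparisons stay inside the scatter, with a 1.7-fold lower number from compound 3 to compound 4 (0.24 log units; within the scatter) and a 1.7-fold lower number from compound 1 to compound 4 (0.24 log units; within the scatter), so compound 4 stands apart only from compound 2 and not from every earlier aryl amide. Nothing shown here explains why the dichloro group sets compound 4 apart from compound 2.

The compounds shown leave open whether a single chlorine would be enough, as in 4-chlorophenyl, or whether both chlorines are needed for a reading like that of compound 4. They also leave open how this place responds to groups of a different kind, such as a phenyl ring bearing trifluoromethyl, a carboxylic acid or an amine, since every group compared so far is a phenyl ring carrying only methyl, fluoro or chloro.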